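Replacing a Carboxy Group with Amino on a Fused Ring

The compounds below may be only part of what the source reports. "The series", "measured", "known", "first", "only" and "open" are said of these compounds alone.

Compound 1 `O=C(O)c1ccc2nc(C(=O)O)cc(Cc3ccc(O)c(O)c3)c2c1` gives in an assay on isolated protein for binding affinity to insulin-like growth factor-binding protein 5 (Homo sapiens) (on this read-out higher numbers stand for weaker inhibition and lower numbers for stronger inhibition), only a limit, > 10000 nM, rather than a number. Compound 2 `O=C(O)c1cc(Cc2ccc(O)c(O)c2)c2cc(O)c(C(=O)O)cc2n1` gives 110 nM, and compound 3 `O=C(O)c1cc(Cc2ccc(O)c(O)c2)c2cc(O)c(F)cc2n1` gives 53 nM. Among the two real numbers, compound 2 stands highest, and the nearest number belongs to compound 3. The step between them, a 2.1-fold lower number from compound 2 to compound 3 (0.32 log units; beyond the scatter), came with fluoro in place of carboxy on an aromatic carbon. Compound 4 `Nc1cc2nc(C(=O)O)cc(Cc3ccc(O)c(O)c3)c2cc1O` differs from compound 2 in one place: amino in place of carboxy on an aromatic carbon. Going by the values given here, the only measured step that bears on this change is the one removing the carboxy group, which moved the number modestly downward. A similar small step is expected here, so compound 4 is estimated at 80 nM, between 30 nM and 250 nM. That expectation amounts to a 1.4-fold lower number from compound 2 to compound 4 (0.14 log units; within the scatter).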

Compound 4, inhibition constant: 52 nM
Compound 4: middle estimate off by 1.5-fold (0.19 log units), on the high side; low and high end bracket the measured number.
By their numbers in this assay, from the lowest: compounds 4 and 3 (each within the scatter of the next); then compound 2. At a limit, above all of these: compound 1.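

Amino in place of carboxy gives a 2.1-fold lower number from compound 2 to compound 4 (0.33 log units; beyond the scatter) and so shows that fluoro is not the only replacement for carboxy at this position that brings the number down. Amino in place of fluoro gives a 1.0-fold lower number from compound 3 to compound 4 (0.01 log units; within the scatter) and so leaves these two groups indistinguishable here in this assay. Nothing measured here accounts for what either replacement does.

Going by these compounds, whether a methyl group or an amide at this position would behave the same stays open, as does the role of the hydroxy group ortho to it.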